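Boc removal on the piperazine dithiocarbamate arm

The source may report more compounds than this note shows. Statements on the series, on what has been measured and on what is new or still open speak of the compounds shown alone.

Two compounds of the series have been run in a functional assay on SW-620 cells (Homo sapiens) for inhibition, read by MTT assay, with a stated time of 72 h (a lower number here means a stronger inhibitor, a higher number a weaker inhibitor), and both sit at the boundary of what the test resolves. Compound 1 `O=c1cc(Cn2cc(CSC(=S)N3CCOCC3)nn2)c2ccc(O)cc2o1` gives only a limit, >= 100000 nM, namely (the limit of >= 100000 nM in this assay, at which 1 of the 2 values shown sits). Compound 2 `CC(C)(C)OC(=O)N1CCN(C(=S)SCc2cn(Cc3cc(=O)oc4cc(O)ccc34)nn2)CC1` likewise gives only a limit, > 100000 nM, namely (the limit of > 100000 nM in this assay, at which 1 of the 2 values shown sits). Going by the values given here, compound 2 therefore has no number of its own to stand on, and the two values together show only that neither compound reaches a measurable half-maximal inhibitory concentration. Compound 3 `O=c1cc(Cn2cc(CSC(=S)N3CCNCC3)nn2)c2ccc(O)cc2o1` differs from compound 2 by hydrogen in place of tert-butoxycarbonyl on an amine nitrogen in a ring. Among the compounds with values here, no measured pair covers this change, so the move from compound 2 to compound 3 in this assay is pure expectation; a shift beyond the scatter is possible but unsupported, and none beyond the scatter is the plainer guess. Compound 3 is expected near 80000 nM, within 20000 nM to 150000 nM. The expected step is an at least 1.2-fold lower number from compound 2 to compound 3 (0.09 log units; that floor lies within the scatter).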

Compound 3, half-maximal inhibitory concentration: > 100000 nM
Compound 3: a limit, no number (the forecaster's own chance of this, stated with the estimate: 60%); middle value at least 1.2-fold (0.09 log units) from the limit.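

Compound 3 gives > 100000 nM in this assay, which is a limit, and neither its step from compound 2 nor its step from compound 1 can be read. The compounds shown leave open whether any change on the dithiocarbamate arm yields a measurable half-maximal inhibitory concentration.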